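This account rests on a few compounds, and the source may have more. Where it says the series, first, only, none or still open, it means among the compounds named here.

The compounds measured in a functional assay on the whole organism (artery, strain albino) with Rattus norvegicus as the target, with a stated time of 300 min, at a dose of 10 mg/kg by the oral route; a higher number here means more inhibition at the dose given (going by the name of the read-out), a lower number less inhibition:
compound 1 `COc1ccc(C2N=C(SCc3cccc(Cl)c3)NC(C)=C2C(=O)Nc2ccc(F)cc2)cc1OC`, where compound 1 gives 16.4%
compound 2 `CC1=C(C(=O)Nc2ccc(F)cc2)C(c2ccc([N+](=O)[O-])cc2)N=C(SCc2ccccc2)N1`, where compound 2 gives 38.5%
compound 3 `CC1=C(C(=O)Nc2ccc(F)cc2)C(c2ccc([N+](=O)[O-])cc2)N=C(SCc2ccccc2Cl)N1`, where compound 3 gives 18.5%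

On these numbers compound 3 stands second highest of three; its nearest neighbour is compound 1, within the scatter, while compound 2 lies furthest from it, beyond the scatter. Compound 4 `CC1=C(C(=O)Nc2ccc(F)cc2)C(c2ccc([N+](=O)[O-])cc2)N=C(SCc2cccc(Cl)c2)N1` has not been measured; it differs from compound 3 in that (3-chlorophenyl in place of 2-chlorophenyl on a saturated chain carbon bound to a sulfur). For the measured compounds named here, the only measured step, a number 20 percentage points lower from compound 2 to compound 3 (beyond the scatter), concerns chloro in place of hydrogen rather than a move of the chloro, so it bears on this change only loosely. Compound 1 carries the same (3-chlorobenzyl)sulfanyl group on a different core and sits within the scatter of compound 3. Compound 4 is therefore expected to show a number 0.5 percentage points lower from compound 3 to compound 4 (within the scatter), no step beyond the scatter. The estimate for compound 4 is 18%, between 8% and 32%.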

Compound 4, a percentage reported as inhibition, in the whole organism at one dose (the size of the read-out at that dose, not a potency): 18.5%
For compound 4 the middle estimate is 0.5 percentage points below the measured one; low and high end bracket the measured number.
By their numbers in this assay, from the lowest: compounds 1, 3 and 4 (each within the scatter of the next); then compound 2.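

In this assay, 3-chlorophenyl in place of 2-chlorophenyl on a saturated chain carbon bound to a sulfur gives no change at the digits printed from compound 3 to compound 4 (within the scatter), so the two chloro placements are not told apart. Chloro in place of hydrogen gives a number 20 percentage points lower from compound 2 to compound 4 (beyond the scatter), so the fall holds for both placements, while 4-nitrophenyl in place of 3,4-dimethoxyphenyl on a saturated ring carbon gives a number 2.1 percentage points higher from compound 1 to compound 4 (within the scatter). No measured evidence accounts for these results.

Open, as far as these compounds go, is whether a methoxy group or an amine in place of chloro on the benzyl ring would stay with compound 4 or come closer to compound 2.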